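The source may hold more compounds than are shown below. What is called first, only, known or untested is meant among the compounds shown, and "the series" means these compounds.

In a functional assay on EC9706 cells (Homo sapiens) for cytotoxicity, read by MTT assay, with a stated time of 72 h (a higher number here means a weaker inhibitor, a lower number a stronger inhibitor), compound 1 `O=C(CSC(=S)N[C@H]1CCOC1=O)Nc1cccc(Cl)c1` gives 107000 nM, a measured number that marks weak activity. Compound 2 `COc1ccc(NC(=O)CSC(=S)N[C@H]2CCOC2=O)cc1` has no exact number, and its result of > 128000 nM is a limit of this assay. Compound 3 `CCCCc1ccc(NC(=O)CSC(=S)N[C@H]2CCOC2=O)cc1` keeps the rest of compound 2 and makes one change: butyl in place of methoxy on an aromatic carbon. This puts butyl in place of methoxy on an aromatic carbon, para to a large group. Going by the values given here, no measured step between closely matched compounds is available as a guide, so this forecast is uncertain. Compound 1 reads 107000 nM, which shows that a close relative can give a number in this assay, so a modest move toward stronger inhibition is expected. The expected change is an at least 1.6-fold lower number from compound 2 to compound 3 (0.20 log units; that floor lies within the scatter). The estimate for compound 3 is 80000 nM, with an expected range of 30000 nM to 128000 nM.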

Compound 3, half-maximal inhibitory concentration: 44200 nM
Estimate against measurement, compound 3: 1.8-fold (0.26 log units) above; low and high end bracket the measured number.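

Going by these compounds alone, at this position, on an aromatic carbon para to a large group, putting butyl in place of methoxy brings an at least 2.8-fold lower number from compound 2 to compound 3 (0.46 log units; beyond the scatter) as the first step that can be sized. In this assay compound 2 gives > 128000 nM and that is a limit of the assay, not a number. From the compounds shown here alone, the step is therefore only a floor and its full size stays unknown, because compound 2 sits at that limit: the limit of > 128000 nM in this assay, at which 1 of the 3 values shown sits.

Going by these compounds, whether the lower number goes with the butyl chain itself or simply with the departure of methoxy stays open. An ethyl group, a hexyl chain or an amine at this same position would be needed to separate those readings, and compound 1 differs from compound 3 in more than one place, so it cannot settle the question.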